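Shrinking a seven-membered ring on the amine nitrogen

This account rests on a few compounds, and the source may have more. Where it says the series, first, only, none or still open, it means among the compounds named here.

Of the compounds shown here, three sharing one core have been measured in a functional assay on CCRF-CEM cells for inhibition of C-X-C chemokine receptor type 4 (Homo sapiens), read by calcium flux; a higher number here means a weaker inhibitor, a lower number a stronger inhibitor. Compound 1 `CN(/C(=N/C1CCCCC1)SCC1=CSC2=NCCN12)C1CCCCC1` gives 931 nM, compound 2 `C1=C(CS/C(=N\C2CCCC2)NC2CCCC2)N2CCN=C2S1` gives 493 nM, and compound 3 `C1=C(CS/C(=N\C2CCCCC2)NC2CCCCCC2)N2CCN=C2S1` gives 6.6 nM. Compound 3 stands clearly apart: it has the lowest number of the three, with compound 2 and compound 1 both well beyond the scatter above it.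

Going by the values given here, the one step between neighbouring structures, a 140-fold lower number from compound 1 to compound 3 (2.15 log units; beyond the scatter), shows how much the group on the carbon with a double bond to nitrogen matters here.

Compound 4 `C1=C(CS/C(=N\C2CCCCC2)NC2CCCC2)N2CCN=C2S1` has not yet been measured. It differs from compound 3 in one place: cyclopentyl in place of cycloheptyl on an amine nitrogen. Among the compounds with values here, no measured pair isolates this exact change. The nearest guide is compound 2, which also carries cyclopentyl on the amine nitrogen and gives a far higher number than compound 3, though compound 2 differs from compound 4 in a second place as well. On that basis the expectation for compound 4 is a weaker inhibitor than compound 3, by a step of a 15-fold higher number from compound 3 to compound 4 (1.18 log units; beyond the scatter). In this assay compound 4 is therefore estimated at 100 nM, with a likely range from 15 nM to 700 nM.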

Compound 4, half-maximal inhibitory concentration: 173 nM
Beside the measured number, compound 4's estimate is 1.7-fold (0.24 log units) below it; the range from low to high includes it.
By their numbers in this assay, from the lowest: compound 3; then compound 4; then compounds 2 and 1 (each within the scatter of the next).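

Compound 3 and compound 4 differ only in the ring on the amine nitrogen, and in this assay cyclopentyl in place of cycloheptyl there gives a 26-fold higher number from compound 3 to compound 4 (1.42 log units; beyond the scatter) as a large step, so ring size at this one place matters a great deal. The ring on the double-bonded nitrogen counts for less among these compounds: with cyclopentyl kept on the amine nitrogen, cyclohexyl in place of cyclopentyl on that nitrogen gives a 2.8-fold lower number from compound 2 to compound 4 (0.45 log units; beyond the scatter) as a modest step. Cyclopentylamino in place of cyclohexyl(methyl)amino gives a 5.4-fold lower number from compound 1 to compound 4 (0.73 log units; beyond the scatter) as another modest step, so a compound with cyclopentyl on an amine nitrogen still falls well short of compound 3 even though it improves on compound 1.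

Nothing here gives a measured reason for why the larger ring gives so much lower a number. Also open, as far as these compounds go, is how the number changes with a cyclohexylamino group at this place, between the five-membered and seven-membered rings, and whether an open chain such as heptyl or a ring larger than cycloheptyl would hold the low number of compound 3.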